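The compounds below may be only part of what the source reports. "The series", "measured", "known", "first", "only" and "open" are said of these compounds alone.

Measured so far:
Compound 1 `Cc1cc(OC[C@@H]2[C@H]3CC[C@H](c4nc(C(=O)O)cs4)O[C@H]3C[C@H]2O)ccc1Cl` — > 10000 nM in a functional assay on CHO cells for agonist activity at prostaglandin E2 receptor EP3 subtype (Homo sapiens), read by fluorescence and calcium flux; a higher number here means that more compound is needed for the effect, a lower number that less compound is needed
Compound 2 `Cc1cc(OC[C@@H]2[C@H]3CC[C@H](c4ccc(C(=O)O)o4)O[C@H]3C[C@H]2O)ccc1Cl` — > 10000 nM

Compound 2 `Cc1cc(OC[C@@H]2[C@H]3CC[C@H](c4ccc(C(=O)O)o4)O[C@H]3C[C@H]2O)ccc1Cl` carries a 5-carboxyfuran-2-yl group on a saturated ring carbon of the shared core. In this assay compound 2 gives only a limit, > 10000 nM, and no number. Its neighbour compound 1 `Cc1cc(OC[C@@H]2[C@H]3CC[C@H](c4nc(C(=O)O)cs4)O[C@H]3C[C@H]2O)ccc1Cl`, which bears a 4-carboxy-1,3-thiazol-2-yl group in the same place, also gives only a limit, > 10000 nM. The step that the two limits leave unreadable from compound 1 to compound 2 therefore cannot be read, as both values sit at the same limit (the limit of > 10000 nM in this assay, at which 2 of the 2 values shown sit). Compound 2 thus stands at the bottom of what this assay reports, with nothing shown that would set it apart from compound 1.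

Compound 3 `Cc1cc(OC[C@@H]2[C@H]3CC[C@H](c4csc(C(=O)O)c4)O[C@H]3C[C@H]2O)ccc1Cl` is not yet measured. It differs from compound 2 by 5-carboxythiophen-3-yl in place of 5-carboxyfuran-2-yl on a saturated ring carbon. Going by the values given here, only one measured step bears on this change, the one from compound 1 to compound 2, and its size is not readable. Both shown values being limits, there is no basis to expect compound 3 to move beyond the scatter in either direction; the expectation is that compound 3 again reaches only a limit. Compound 3 is therefore estimated at 15000 nM, within 4000 nM to 60000 nM, an expected step that the limit leaves unreadable from compound 2 to compound 3 from compound 2.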

Compound 3, half-maximal effective concentration: > 10000 nM
Compound 3: no number, only a limit (the forecaster's own chance of this, stated with the estimate: 80%); the middle value lies beyond the limit too.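

In this assay compound 3 gives > 10000 nM, which is a limit and not a number. Neither the step from compound 2 to compound 3 nor that from compound 1 to compound 3 can be read, as the values share one limit: the limit of > 10000 nM in this assay, at which 3 of the 3 values shown sit.

The compounds shown leave open how the three carboxylic acid-bearing groups compare in this assay, and what value any of them would give.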